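Branched or straight: a chain swap on the spiro-amide

The source may hold more compounds than are shown below. What is called first, only, known or untested is meant among the compounds shown, and "the series" means these compounds.

Measured compounds:
Compound 1 `N=C(N)c1ccc(N2CCC3(CCC(C(=O)NCCCC(=O)O)CC3)CC2)cc1`, 37100 nM
Compound 2 `C[C@@H](CC(=O)O)NC(=O)C1CCC2(CC1)CCN(c1ccncc1)CC2`, 14300 nM

In a functional assay with Homo sapiens as the target (a lower number here means a stronger inhibitor, a higher number a weaker inhibitor), compound 2 gives 14300 nM, the lower of the two numbers; in the same assay compound 1 gives 37100 nM, and the gap between them lies beyond the usual scatter. Compound 1 and compound 2 differ in more than one place at once, so neither carries a single measured step.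

Compound 3 `O=C(O)CCCNC(=O)C1CCC2(CC1)CCN(c1ccncc1)CC2` keeps the core of compound 2 and alters only the acid-bearing chain: 3-carboxypropyl in place of 1-(carboxymethyl)ethyl on an amide-type nitrogen. The chain loses its branch and its single stereocentre and becomes straight, while the amide, the acid and the atom count stay the same. Among the compounds with values here, no measured pair isolates this change. For the step from compound 2 to compound 3 a small shift is expected, if any, toward a weaker inhibitor, roughly at the edge of the scatter, as a 1.4-fold higher number from compound 2 to compound 3 (0.15 log units; within the scatter). Compound 3 is therefore estimated at 20000 nM, with a range from 7000 nM to 60000 nM.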

Compound 3, half-maximal inhibitory concentration: 12000 nM
The estimate for compound 3 lay 1.7-fold (0.22 log units) above the measured number; the range from low to high includes it.
By their numbers in this assay, from the lowest: compounds 3 and 2 (each within the scatter of the next); then compound 1.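

In this assay, straightening the chain gives a 1.2-fold lower number from compound 2 to compound 3 (0.08 log units; within the scatter) and so shows that, on this amide-type nitrogen, the branch and its defined stereocentre can be lost with no change that stands out from the scatter. Compound 3 also links the other two compounds through a single place: on the amine nitrogen in a ring, the group of 6 heavy atoms with a hetero atom in its aromatic ring, in place of the group of 9 heavy atoms with a carbon-only aromatic ring, gives a 3.1-fold lower number from compound 1 to compound 3 (0.49 log units; beyond the scatter) as a modest step. No measurement here explains either step. Going by these compounds, what a longer chain on the amide nitrogen, or a methyl ester in place of the carboxylic acid, would do remains open. So does the effect of the opposite stereocentre in the branched chain.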